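The source may hold more compounds than are shown below. What is called first, only, known or untested is meant among the compounds shown, and "the series" means these compounds.

Of the compounds shown here, three sharing one core have been measured in a functional assay (QGY7701 cells, Homo sapiens) for inhibition, read by MTT assay, with a stated time of 48 h; on this read-out higher numbers stand for weaker inhibition and lower numbers for stronger inhibition. Compound 1 `Cc1ccccc1NC(=O)/C=C/c1coc2cc(O)ccc2c1=O` gives 9320 nM. Compound 2 `COc1ccc(CNC(=O)/C=C/c2coc3cc(OC)ccc3c2=O)cc1` gives 15700 nM. Compound 3 `Cc1ccc(CNC(=O)/C=C/c2coc3cc(O)ccc3c2=O)cc1` gives 24900 nM. Among these three numbers compound 2 stands second highest, but its gaps to compound 3 and to compound 1 both lie within the scatter, so no order among the three can be claimed. One step between compounds differing in a single place is known: a 2.7-fold higher number from compound 1 to compound 3 (0.43 log units; beyond the scatter), a modest weakening. Compound 4 `COc1cccc(NC(=O)/C=C/c2coc3cc(OC)ccc3c2=O)c1` has not yet been measured; its change from compound 2 is 3-methoxyphenyl in place of 4-methoxybenzyl on an amide-type nitrogen. The measured step swaps a phenyl group on the amide-type nitrogen for a benzyl group and gives a higher number; the change to compound 4 runs the opposite way, a benzyl group giving way to a phenyl group, though the substituent is methoxy rather than methyl. A modest lowering of the number is therefore expected, about a 2.0-fold lower number from compound 2 to compound 4 (0.29 log units; within the scatter). Compound 4 is estimated at 8000 nM, with a range from 3000 nM to 22000 nM.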

Compound 4, half-maximal inhibitory concentration: 39100 nM
Compound 4: the middle estimate sits 4.9-fold (0.69 log units) below what was measured, outside the stated range (above it).
By their numbers in this assay, from the lowest: compounds 1, 2, 3 and 4 (each within the scatter of the next, the first and the last beyond it).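

In this assay, 3-methoxyphenyl in place of 4-methoxybenzyl on the amide-type nitrogen gives a 2.5-fold higher number from compound 2 to compound 4 (0.40 log units; beyond the scatter), so here the phenyl group carries the higher number, whereas the earlier swap gave a 2.7-fold higher number from compound 1 to compound 3 (0.43 log units; beyond the scatter), with the benzyl group carrying the higher number. The direction of a swap between phenyl and benzyl groups on this nitrogen therefore does not carry over from one pair to the other, and the two pairs differ both in the aromatic substituent, methyl or methoxy, and in the core, which has hydroxy in compounds 1 and 3 and methoxy in compounds 2 and 4. Nothing available explains the opposite directions.

From the compounds shown here alone, it remains open whether the direction follows the substituent on the aromatic ring or the group on the core. Going by these compounds, how a 2-phenylethyl group or a carboxylic acid on the aromatic ring would read on this nitrogen also remains open.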